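Swapping hydroxy for phenyl on a weak growth inhibitor

The compounds below may be only part of what the source reports. "The series", "measured", "known", "first", "only" and "open" are said of these compounds alone.

Within the data shown here, in a functional assay on BT-549 cells (Homo sapiens) for inhibition, read by sulforhodamine B assay, with a stated time of 48 h (a higher number here means a weaker inhibitor of growth, a lower number a stronger inhibitor of growth), compound 1 (`Cc1nnc(-c2nn(-c3ccccc3)c(-c3ccccc3)c2C#N)c2cn(-c3ccccc3)nc12`) gives 96800 nM, and compound 2 (`N#Cc1c(-c2nnc(O)c3nn(-c4ccccc4)cc23)nn(-c2ccccc2)c1-c1ccccc1`) gives 44800 nM, the lower of the two numbers so far. Compound 3 (`N#Cc1c(-c2nnc(-c3ccccc3)c3nn(-c4ccccc4)cc23)nn(-c2ccccc2)c1-c1ccccc1`) has phenyl in place of hydroxy on an aromatic carbon. Among the measured compounds shown here, only one measured step bears on this hydroxy, the modest 2.2-fold lower number from compound 1 to compound 2 (0.33 log units; beyond the scatter), and no measured compound yet carries phenyl there. In this assay, only a small rise, not beyond the scatter, is therefore expected: a 1.3-fold higher number from compound 2 to compound 3 (0.13 log units; within the scatter). Compound 3 is estimated at 60000 nM, with an expected range of 20000 nM to 150000 nM.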

Compound 3, concentration for 50% growth inhibition: 21800 nM
Compound 3: middle estimate off by 2.8-fold (0.44 log units), on the high side; low and high end bracket the measured number.
By their numbers in this assay, from the lowest: compound 3; then compound 2; then compound 1.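

At this aromatic carbon, a whole phenyl ring is accepted and improves on the smaller groups: a 2.1-fold lower number from compound 2 to compound 3 (0.31 log units; beyond the scatter) in this assay, and a 4.4-fold lower number from compound 1 to compound 3 (0.65 log units; beyond the scatter) against methyl, both modest but beyond the scatter. The position therefore ranks the three groups as phenyl, then hydroxy, then methyl, from the lowest number to the highest. Nothing available explains this order. The compounds shown leave open whether a pyridyl ring or a benzyl group would do as well as phenyl. They also leave open how an amine or a carboxylic acid would fare at this carbon.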